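A triazolyl group in place of 2-(pyrrolidin-1-yl)ethyl

A few compounds are considered here, and "the series" means these few. Any claim that something is new, unique, unknown or untested is made for them only; others in the source may bear on it.

Of the compounds shown here, two sharing one core have been measured in a functional assay on M14 cells (Homo sapiens) for inhibition; on this read-out lower numbers stand for stronger inhibition of growth and higher numbers for weaker inhibition of growth. Compound 1 `C=C1C(=O)O[C@H]2[C@H]1CC/C(COC(=O)N1CCC(F)(F)CC1)=C\CC[C@@]1(C)O[C@@H]21` gives 2840 nM, and compound 2 `C=C1C(=O)O[C@H]2[C@H]1CC/C(COC(=O)NCCN1CCCC1)=C\CC[C@@]1(C)O[C@@H]21` gives 9650 nM, the higher of the two numbers and so the weaker inhibition of growth. Compound 3 `C=C1C(=O)O[C@H]2[C@H]1CC/C(COC(=O)Nc1n[nH]c(SC)n1)=C\CC[C@@]1(C)O[C@@H]21` keeps the core of compound 2 but carries 5-(methylsulfanyl)-1H-1,2,4-triazol-3-yl in place of 2-(pyrrolidin-1-yl)ethyl on an amide-type nitrogen.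

Among the measured compounds shown here, only one measured step bears on this change. It also alters the group on the carbonyl carbon and reads a 3.4-fold higher number from compound 1 to compound 2 (0.53 log units; beyond the scatter), a modest step beyond the scatter. Compound 1 lacks the 2-(pyrrolidin-1-yl)ethyl group and has the lower number at 2840 nM, so a move away from that group in compound 3 is expected to lower the number as well. For the measured compounds named here, no measured compound carries the triazolyl group, so this expectation is loose. The estimated step is a 1.9-fold lower number from compound 2 to compound 3 (0.29 log units; within the scatter), similar in size to the measured one or smaller. For compound 3 the estimated value is 5000 nM, with an expected range from 1800 nM to 14000 nM.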

Compound 3, concentration for 50% growth inhibition: 1590 nM
Estimate against measurement, compound 3: 3.1-fold (0.50 log units) above; measured number below the stated range.
By their numbers in this assay, from the lowest: compounds 3 and 1 (each within the scatter of the next); then compound 2.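

In this assay, the amide-type nitrogen accepts 5-(methylsulfanyl)-1H-1,2,4-triazol-3-yl, a five-membered aromatic ring attached directly to that nitrogen, and exchanging 2-(pyrrolidin-1-yl)ethyl for it gives a 6.1-fold lower number from compound 2 to compound 3 (0.78 log units; beyond the scatter). Set against the other group on the carbonyl carbon, (5-(methylsulfanyl)-1H-1,2,4-triazol-3-yl)amino in place of 4,4-difluoropiperidin-1-yl gives a 1.8-fold lower number from compound 1 to compound 3 (0.25 log units; within the scatter), so this read-out does not separate the two, and among the three compounds only compound 2, with its 2-(pyrrolidin-1-yl)ethyl group, stands apart. No measurement is available that would account for these steps.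

The compounds shown leave open whether the methylsulfanyl group contributes to the lower number of compound 3, a point that the same triazolyl ring carrying a methyl group or an amine in its place would address. They also leave open whether the higher number of compound 2 goes with the pyrrolidine ring or with the ethyl chain that carries it, which a 2-(piperidin-1-yl)ethyl or a longer 3-(pyrrolidin-1-yl)propyl group on the same nitrogen would help to separate.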